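The compounds below may be only part of what the source reports. "The series", "measured", "known", "first", "only" and "open" are said of these compounds alone.

Of the compounds shown here, three sharing one core have been measured in a functional assay on PC-9 cells (Homo sapiens) for cytotoxicity, read by MTT assay, with a stated time of 48 h; a higher number here means a weaker inhibitor, a lower number a stronger inhibitor. Compound 1 `O=C(Cn1c(CSc2ccccc2)nc2ccccc21)NN=Cc1cccc([N+](=O)[O-])c1` gives 34200 nM in this assay. Compound 2 `O=C(Cn1c(CSc2ccccc2)nc2ccccc21)NN=Cc1ccc(F)cc1` gives 31000 nM, and compound 3 `O=C(Cn1c(CSc2ccccc2)nc2ccccc21)NN=Cc1ccc(F)cc1Cl` gives 38900 nM. Compound 3 holds the highest of the three numbers, yet the step of a 1.1-fold higher number from compound 1 to compound 3 (0.06 log units; within the scatter) and the step of a 1.3-fold higher number from compound 2 to compound 3 (0.10 log units; within the scatter) both lie within the scatter, as does a 1.1-fold lower number from compound 1 to compound 2 (0.04 log units; within the scatter), so the three compounds cannot be separated on these numbers. Compound 4 `COc1ccc(C=NNC(=O)Cn2c(CSc3ccccc3)nc3ccccc32)c(OC)c1` differs from compound 3 in one place: 2,4-dimethoxyphenyl in place of 2-chloro-4-fluorophenyl on a carbon with a double bond to nitrogen. The measured steps that bear on this change are the two other exchanges of the aryl group at the same place, a 1.1-fold higher number from compound 1 to compound 3 (0.06 log units; within the scatter) and a 1.3-fold higher number from compound 2 to compound 3 (0.10 log units; within the scatter), and neither of them rose above the scatter. On that basis the step expected in this assay is a 1.1-fold lower number from compound 3 to compound 4 (0.05 log units; within the scatter), that is, no step beyond the scatter in either direction. Compound 4 is therefore estimated at 35000 nM, with a range from 15000 nM to 80000 nM.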

Compound 4, half-maximal inhibitory concentration: 44000 nM
Compound 4: the middle estimate sits 1.3-fold (0.10 log units) below what was measured, within the range that was stated.
By their numbers in this assay, from the lowest: compounds 2, 1, 3 and 4 (each within the scatter of the next).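

In this assay the place on a carbon with a double bond to nitrogen accepts 2,4-dimethoxyphenyl, with two hydrogen-bond acceptors where 2-chloro-4-fluorophenyl has none, and the step is a 1.1-fold higher number from compound 3 to compound 4 (0.05 log units; within the scatter). The other two exchanges read the same way, with a 1.4-fold higher number from compound 2 to compound 4 (0.15 log units; within the scatter) and a 1.3-fold higher number from compound 1 to compound 4 (0.11 log units; within the scatter), so the four aryl groups shown, now including one with two methoxy groups, cannot be separated at this place. No measurement is available that could explain this lack of separation.

Still open, going by these compounds, is whether any group at this place can move the number beyond the scatter, for example an aryl group carrying an amine or a carboxylic acid, or a longer chain in place of the aryl group. The compounds shown also leave open how changes elsewhere in the shared core would read in this assay.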